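A few compounds are considered here, and "the series" means these few. Any claim that something is new, unique, unknown or untested is made for them only; others in the source may bear on it.

Compound 3 `Cn1nnnc1SCC(=O)Nc1ccc(-c2nc(-c3ccccc3)c(-c3ccccc3)n2C)cc1` stands second highest of the three compounds measured in a functional assay on MCF7 cells (Homo sapiens) for cytotoxicity, read by MTT assay, with a stated time of 24 h, tested at 80 ug/mL (a higher number here means a stronger effect of the compound at the concentration tested, a lower number a weaker effect), where compound 3 gives 77.7%. Its nearest neighbour is compound 1 `Cn1c(-c2ccc(NC(=O)CSc3nc4ccccc4s3)cc2)nc(-c2ccccc2)c1-c1ccccc1`, which in this assay gives 76.6%, a gap that stays within the usual scatter (a number 1.1 percentage points higher from compound 1 to compound 3 (within the scatter)). Compound 2 `Cn1cnnc1SCC(=O)Nc1ccc(-c2nc(-c3ccccc3)c(-c3ccccc3)n2C)cc1` gives 89.3% in this assay, and the step of a number 11.6 percentage points lower from compound 2 to compound 3 (beyond the scatter) lies beyond the scatter.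

Compound 4 `Cn1c(-c2ccc(NC(=O)CSC3=NCCS3)cc2)nc(-c2ccccc2)c1-c1ccccc1` differs from compound 3 only at the ring on the sulfur: a group of 5 heavy atoms (3 carbon, 1 nitrogen, 1 sulfur; one five-membered non-aromatic ring with 2 hetero atoms) in place of a group of 6 heavy atoms (2 carbon, 4 nitrogen; one five-membered aromatic ring with 4 hetero atoms), on a sulfur. The two earlier swaps of that ring moved the number within the scatter or modestly, so the step of a number 0.3 percentage points higher from compound 3 to compound 4 (within the scatter) is expected to be small. Compound 4 is therefore estimated at 78%, within 65% to 90%, in this assay.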

Compound 4, a percentage reported as activity, at one concentration (the size of the read-out at that concentration, not a potency): 70%
Compound 4: the middle estimate sits 8 percentage points above what was measured; measured number inside the range.
By their numbers in this assay, from the lowest: compounds 4, 1 and 3 (each within the scatter of the next); then compound 2.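

Compound 4 is the first of these compounds with a non-aromatic ring on the sulfur, and in this assay it cannot be told apart from compound 3 (a number 7.7 percentage points lower from compound 3 to compound 4 (within the scatter)) or compound 1 (a number 6.6 percentage points lower from compound 1 to compound 4 (within the scatter)). Only compound 2 stands apart (a number 19.3 percentage points lower from compound 2 to compound 4 (beyond the scatter)), the largest step seen at this position. Among these compounds, then, an aromatic ring on the sulfur is not required to match compound 1 and compound 3.

On these data alone, whether an amine, a carboxylic acid or an open carbon chain on the sulfur would keep this level remains open. No available measurement explains why compound 2 stands apart.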